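Hydroxy to tert-Butyl: Expected Effect on Compound 3

The source may hold more compounds than are shown below. What is called first, only, known or untested is meant among the compounds shown, and "the series" means these compounds.

Two compounds of the series carry a number in a physicochemical assay, read by spectrophotometry, with a stated time of 60 min, tested at 100 uM; a lower number here means a weaker effect, a higher number a stronger effect of the compound at the concentration tested. Compound 1 `O=C(N/N=C/c1ccc(O)cc1)c1ccc(O)cc1` gives 38%, the higher of the two. Compound 2 `COc1ccc(/C=C/C=N/NC(=O)c2ccc(C(C)(C)C)cc2)cc1` carries a tert-butyl and a methoxy and differs from compound 1 in several places. In this assay compound 2 gives 8.3%. The gap from compound 1 down to this number lies beyond the scatter. Going by the values given here, no pair of measured compounds differs in one place only, so no single step has yet been measured.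

Compound 3 `CC(C)(C)c1ccc(C(=O)N/N=C/c2ccc(O)cc2)cc1` is the next compound. It differs from compound 1 by tert-butyl in place of hydroxy on an aromatic carbon, on an aromatic carbon of a six-membered aromatic ring of carbon only, para to a large group; the hydroxy on the other ring stays. Among the compounds with values here, the only guide is compound 2, whose tert-butyl comes with 8.3%, well under compound 1. The expected direction is downward, by a step beyond the scatter, though smaller than the gap to compound 2; compound 3 keeps a hydroxy that compound 2 lacks. Compound 3 is expected to give 18%, between 4% and 34%, an expected step of a number 20 percentage points lower from compound 1 to compound 3 (beyond the scatter).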

Compound 3, a percentage reported as inhibition, at one concentration (the size of the read-out at that concentration, not a potency): 15%
Beside the measured number, compound 3's estimate is 3 percentage points above it, within the range that was stated.
By their numbers in this assay, from the lowest: compounds 2 and 3 (each within the scatter of the next); then compound 1.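

In this assay the series now has its first step that changes one place only: tert-butyl in place of hydroxy on an aromatic carbon, para to a large group, gives a number 23 percentage points lower from compound 1 to compound 3 (beyond the scatter) while the hydroxy on the other ring stays. The read-out at this concentration therefore responds to a change at this position alone, and the size of the response no longer has to be inferred from compounds that differ in several places. Going by these compounds alone, nothing measured so far bears on the reason for this step.

One swap removes hydroxy and brings in tert-butyl at once, so these compounds cannot show whether the step follows from the loss of the first group, the arrival of the second, or both. Also open, on these data alone, are the outcomes with a group such as methyl, an amine or a carboxylic acid at this position, and the effect of a change to the hydroxy on the other ring, which stays the same from compound 1 to compound 3 and so remains untested as a single step.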